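Working notes: amine extension in a diarylmethane series

The source may hold more compounds than are shown below. What is called first, only, known or untested is meant among the compounds shown, and "the series" means these compounds.

Measured so far in a functional assay on HEK293T cells for agonist activity at trace amine-associated receptor 1 (Mus musculus), read by BRET and cAMP accumulation; a higher number here means that more compound is needed for the effect, a lower number that less compound is needed:
Compound 1 `CC(=O)Nc1ccc(Cc2ccc(OCCN)cc2)cc1` gives only a limit, > 10000 nM.
Compound 2 `CC(=O)NCCOc1ccc(Cc2ccc(NC(C)=O)cc2)cc1` gives only a limit, > 10000 nM.
Compound 3 `CC(=O)Nc1ccc(Cc2ccc(OCCN)cc2C)cc1` gives only a limit, > 10000 nM.

Compound 3 therefore stands at the limit, and so do the other two values shown (the limit of > 10000 nM in this assay, at which 3 of the 3 values shown sit). The steps a step that the two limits leave unreadable from compound 1 to compound 2 and a step that the two limits leave unreadable from compound 1 to compound 3 are both unreadable for that reason, so no measured step gives a readable size to carry forward.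

Compound 4 `CC(=O)Nc1ccc(Cc2ccc(OCCNC(=N)NC(=N)N)cc2C)cc1` differs from compound 3 by a group of 6 heavy atoms (2 carbon, 4 nitrogen; no ring) in place of a hydrogen atom, on an amine nitrogen. Neither measured step bears on this change in a readable way; the direction and size of an at least 2.0-fold lower number from compound 3 to compound 4 (0.30 log units; that floor lies within the scatter) are expected without measured support, with a real chance that compound 4 again reaches only the limit. Compound 4 is estimated at 5000 nM, range 800 nM to 20000 nM.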

Compound 4, half-maximal effective concentration: > 10000 nM
Compound 4: a limit, no number (the forecaster's own chance of this, stated with the estimate: 50%); middle value at least 2.0-fold (0.30 log units) from the limit.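

The step from compound 3 to compound 4 cannot be read, since both compounds give only a limit: the limit of > 10000 nM in this assay, at which 4 of the 4 values shown sit.

The compounds shown leave open whether any of these changes shifts the agonist response at all.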